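Cytotoxicity series: three compounds sit at the assay limit

The compounds below may be only part of what the source reports. "The series", "measured", "known", "first", "only" and "open" are said of these compounds alone.

Compound 1 `CC(C)C[C@]1(O)NC(=O)[C@]2(OC(Cc3ccccc3)=CC2=O)[C@H]1O`, compound 2 `Cc1cc2c(c(=O)[nH]1)OC(C(=O)CC(C)C)O2` and compound 3 `CC(C)CC(=O)C1Oc2cc(Cc3ccccc3)[nH]c(=O)c2O1` have been run in a functional assay on TE-8 cells (Homo sapiens) for cytotoxicity, read by WST assay, with a stated time of 48 h; on this read-out higher numbers stand for weaker inhibition and lower numbers for stronger inhibition. In this assay compound 1 gives > 100000 nM, which is a limit of the assay and not a number. In this assay compound 2 gives > 100000 nM, also a limit of the assay. In this assay compound 3 gives > 100000 nM, again a limit of the assay. The common picture is the limit of > 100000 nM in this assay, at which 3 of the 3 values shown sit.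

Compound 3 and compound 2 differ in one place: hydrogen in place of phenyl on a saturated chain carbon bound to an aromatic carbon. The step that the two limits leave unreadable from compound 3 to compound 2; with both values at the limit, its size cannot be read.

Compound 4 `CC1=CC(=O)[C@]2(O1)C(=O)N[C@@](O)(CC(C)C)[C@@H]2O` has not been measured in this assay. It differs from compound 1 by hydrogen in place of phenyl on a saturated chain carbon bound to a double-bonded ring carbon. This is the same kind of change as that from compound 3 to compound 2, but not the same: in the measured pair the place is on a saturated chain carbon bound to an aromatic carbon, whereas in compound 1 the place is on a saturated chain carbon bound to a double-bonded ring carbon. The difference between the core of compound 1 and the core of compound 3 is not broken down here.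

Compound 4 is expected to show a step that the limit leaves unreadable from compound 1 to compound 4, an expectation resting on the limit of compound 1 and on (the limit of > 100000 nM in this assay, at which 3 of the 3 values shown sit). Compound 4 is expected at 200000 nM, between 50000 nM and 1000000 nM, and most likely reported as a limit of the assay once more.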

Compound 4, half-maximal inhibitory concentration: > 100000 nM
Compound 4 gave a limit, no number; the forecaster's own chance of this, stated with the estimate: 85%; the middle value does not contradict the limit.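

In this assay compound 4 gives > 100000 nM, a limit of the assay and not a number. With compound 1 also at a limit, no new step can be read between compound 1 and compound 4. The series stays where it was: the limit of > 100000 nM in this assay, at which 4 of the 4 values shown sit.

The compounds shown leave open whether any change on these cores gives a readable value in this assay, and so what benzyl to methyl does to cytotoxicity.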